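Fluoro for methyl on the phenol ring of compound 2

The source may report more compounds than this note shows. Statements on the series, on what has been measured and on what is new or still open speak of the compounds shown alone.

Compound 2 `Cc1ccc(O)c(/C=N/c2ccc(OCc3ccccc3)cc2)c1` gives 24600 nM in an assay on isolated protein for inhibition of Amine oxidase [flavin-containing] B (Homo sapiens), read by fluorescence and Amplex Red, with stated times of 15 min and 20 min (on this read-out higher numbers stand for weaker inhibition and lower numbers for stronger inhibition), the higher of the two numbers recorded there. Going by the values given here, its nearest neighbour is compound 1 `Oc1cccc(/C=N/c2ccc(OCc3ccccc3)cc2)c1O`, which gives 6870 nM in this assay; the single known step, a 3.6-fold higher number from compound 1 to compound 2 (0.55 log units; beyond the scatter), replaces the 2,3-dihydroxyphenyl group with a 2-hydroxy-5-methylphenyl group. Compound 3 `Oc1ccc(F)cc1/C=N/c1ccc(OCc2ccccc2)cc1` differs from compound 2 by fluoro in place of methyl on an aromatic carbon. Among the compounds with values here, no measured step exchanges one small substituent for another at this position, so the one step recorded does not bear directly on this change, and the closest comparison is only that compound 2 itself already stands at the weaker end. A step of a 1.2-fold lower number from compound 2 to compound 3 (0.09 log units; within the scatter) is therefore expected for compound 3, which is to say no change beyond the scatter. Compound 3 is estimated at 20000 nM in this assay, within a range of 7000 nM to 60000 nM.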

Compound 3, half-maximal inhibitory concentration: 15300 nM
Estimate against measurement, compound 3: 1.3-fold (0.12 log units) above, within the range that was stated.
By their numbers in this assay, from the lowest: compound 1; then compounds 3 and 2 (each within the scatter of the next).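

In this assay, going by these compounds alone, fluoro and methyl at this position, para to a hydroxy group, cannot be told apart (a 1.6-fold lower number from compound 2 to compound 3 (0.21 log units; within the scatter)), so exchanging one for the other is the first change here that stays within the scatter. The 2,3-dihydroxyphenyl group of compound 1 also keeps its lead over the 5-fluoro-2-hydroxyphenyl group (a 2.2-fold higher number from compound 1 to compound 3 (0.35 log units; beyond the scatter)), so that lead is not tied to the methyl group of compound 2 alone. Nothing at hand explains either result.

The compounds shown leave open whether a chloro group, a methoxy group or an amine at this position would shift the number beyond the scatter. They also leave open whether the lead of compound 1 rests on its second hydroxy group or on having neither methyl nor fluoro on the ring.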